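The source may report more compounds than this note shows. Statements on the series, on what has been measured and on what is new or still open speak of the compounds shown alone.

Measured compounds:
- compound 1, `CC(C)(C)c1ccc(C(=O)N2CCC3(CC2)C(=O)N(CC(=O)N2CCNCC2)CN3c2ccccc2)cc1`, 22000 nM
- compound 2, `CC(C)(C)c1ccc(C(=O)N2CCC3(CC2)C(=O)N(CC(=O)NCCN)CN3c2ccccc2)cc1`, 7000 nM

Both compounds were tested in an assay on HEK293 cells for displacement of a labelled ligand from NPC1-like intracellular cholesterol transporter 1 (Homo sapiens); on this read-out higher numbers stand for weaker inhibition and lower numbers for stronger inhibition. Among the two numbers available, compound 1 gives the highest, and its nearest neighbour is compound 2, reached by a 3.1-fold lower number from compound 1 to compound 2 (0.50 log units; beyond the scatter), a modest step that replaces piperazin-1-yl with (2-aminoethyl)amino on a carbonyl carbon.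

The unmeasured compound 3, `CCOC(=O)C1CCN(C(=O)CN2CN(c3ccccc3)C3(CCN(C(=O)c4ccc(C(C)(C)C)cc4)CC3)C2=O)CC1`, differs from compound 1 at the same carbonyl carbon: 4-(ethoxycarbonyl)piperidin-1-yl in place of piperazin-1-yl on a carbonyl carbon. For the measured compounds named here, the only measured step that touches this position is the one from compound 1 to compound 2, and it shows that exchanging the piperazin-1-yl group there can move the number by a modest amount. The group entering in compound 3 is larger and carries no hydrogen-bond donor, so that step is only a loose guide to direction; a step of similar or smaller size, in either direction, or none beyond the scatter, seems plausible in this assay. Compound 3 is therefore expected to give about 16000 nM, within a range from 4000 nM to 60000 nM, which means an expected step of a 1.4-fold lower number from compound 1 to compound 3 (0.14 log units; within the scatter).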

Compound 3, half-maximal inhibitory concentration: 3100 nM
Compound 3: middle estimate off by 5.2-fold (0.71 log units), on the high side; the whole stated range lies above it.
By their numbers in this assay, from the lowest: compound 3; then compound 2; then compound 1.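

In this assay, the position on the carbonyl carbon turns out to accept a clearly bigger group with a lower number, not only a small open chain: swapping piperazin-1-yl (6 heavy atoms) for 4-(ethoxycarbonyl)piperidin-1-yl (11 heavy atoms) gives a 7.1-fold lower number from compound 1 to compound 3 (0.85 log units; beyond the scatter) and a step larger than the only one seen here before. The same group also improves on the open chain, with a 2.3-fold lower number from compound 2 to compound 3 (0.35 log units; beyond the scatter) so that among these three compounds the lowest number belongs to the group that carries no hydrogen-bond donor, while the two groups that came before it both contain a nitrogen that the new group lacks in that form. Nothing available here gives a measured reason for these shifts.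

Several things change at once in this swap, so the compounds shown leave open whether the ethoxycarbonyl group itself matters or whether the piperidine ring alone accounts for most of the step. A plain piperidin-1-yl group, a carboxylic acid in place of the ethyl ester, or a longer chain on that ester would each help to separate these possibilities.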